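A few compounds are considered here, and "the series" means these few. Any claim that something is new, unique, unknown or untested is made for them only; others in the source may bear on it.

Three close relatives share one core and differ only in the aryl group on the carbonyl carbon of their amide. Compound 1 `Cc1ccc(C(=O)Nc2cccc(-c3oc4cc(-c5ccc(F)cc5)ccc4c(=O)c3O)c2)cc1` gives 12900 nM in a functional assay on GTL 16 cells for antiproliferative activity against GTL 16 cell line (Homo sapiens), read by CCK-8 assay, with a stated time of 72 h; on this read-out higher numbers stand for weaker inhibition and lower numbers for stronger inhibition; compound 2 `COc1ccc(C(=O)Nc2cccc(-c3oc4cc(-c5ccc(F)cc5)ccc4c(=O)c3O)c2)c(F)c1` gives 15300 nM; compound 3 `O=C(Nc1cccc(-c2oc3cc(-c4ccc(F)cc4)ccc3c(=O)c2O)c1)c1ccc(Cl)nc1` gives 7520 nM, the lowest of the three numbers. The steps between them were small: a 1.7-fold lower number from compound 1 to compound 3 (0.23 log units; within the scatter) and a 2.0-fold lower number from compound 2 to compound 3 (0.31 log units; beyond the scatter), while a 1.2-fold higher number from compound 1 to compound 2 (0.07 log units; within the scatter). Compound 4 `N#Cc1ccc(C(=O)Nc2cccc(-c3oc4cc(-c5ccc(F)cc5)ccc4c(=O)c3O)c2)cc1` carries 4-cyanophenyl in place of 6-chloropyridin-3-yl on a carbonyl carbon. Because a 1.7-fold lower number from compound 1 to compound 3 (0.23 log units; within the scatter) and a 2.0-fold lower number from compound 2 to compound 3 (0.31 log units; beyond the scatter) were both modest swaps at this same position, compound 4 is expected to shift only slightly, a 1.3-fold higher number from compound 3 to compound 4 (0.10 log units; within the scatter), perhaps back toward the numbers of compound 1 and compound 2. Compound 4 is therefore estimated at 9500 nM, within a range from 4500 nM to 20000 nM.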

Compound 4, half-maximal inhibitory concentration: 31800 nM
Compound 4: middle estimate off by 3.3-fold (0.52 log units), on the low side; measured number outside the range, above it.
By their numbers in this assay, from the lowest: compounds 3, 1 and 2 (each within the scatter of the next, the first and the last beyond it); then compound 4.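

In this assay, the aryl group on the carbonyl carbon matters more than the first three compounds suggested: compound 4 is the weakest of the four, with a 4.2-fold higher number from compound 3 to compound 4 (0.63 log units; beyond the scatter) and a 2.1-fold higher number from compound 2 to compound 4 (0.32 log units; beyond the scatter) and also a 2.5-fold higher number from compound 1 to compound 4 (0.39 log units; beyond the scatter) in the numbers. That last step is the cleanest, as a single swap of cyano in place of methyl on an aromatic carbon moves the number beyond the scatter. Nothing shown here explains why this swap weakens inhibition. On these data alone, whether a carboxylic acid or an amine on this ring would behave like cyano stays open. So does the effect of a plain alkyl chain in place of the aryl group.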